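From 3-methylphenyl to 3-ethylphenyl in compound 3

A few compounds are considered here, and "the series" means these few. Any claim that something is new, unique, unknown or untested is made for them only; others in the source may bear on it.

- compound 1 `O=C1NCCN1c1ccc(S(=O)(=O)Nc2ccc3[nH]ccc3c2)cc1` – 260 nM
- compound 2 `Cc1cccc(NS(=O)(=O)c2ccc(N3CCNC3=O)cc2)c1` – 180 nM

In a functional assay on L1210 cells (Mus musculus) for antiproliferative activity, read by sulforhodamine B assay, with a stated time of 48 h (on this read-out lower numbers stand for stronger inhibition and higher numbers for weaker inhibition), compound 2 reads 180 nM and compound 1 reads 260 nM in the same test. These two numbers sit within the usual scatter of repeated measurements, so neither compound can be ranked over the other. Compound 2 is therefore a sound starting point, but not a clear leader.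

Compound 3 `CCc1cccc(NS(=O)(=O)c2ccc(N3CCNC3=O)cc2)c1` differs from compound 2 in one place (methyl in place of hydrogen on a saturated chain carbon bound to an aromatic carbon): methyl in place of hydrogen on a saturated chain carbon bound to an aromatic carbon. Methyl thus becomes ethyl, and 3-methylphenyl becomes 3-ethylphenyl.

Within the data shown here, no measured pair differs in only one place, so the data offer no direct guide to the size of such a step. For so small a change, no step beyond the scatter is expected in this assay, and no direction can be firmly called. The estimated change is a 1.1-fold higher number from compound 2 to compound 3 (0.05 log units; within the scatter) (an expectation, not a measurement). For compound 3 the estimated value is 200 nM (expected range 90 nM to 450 nM).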

Compound 3, half-maximal inhibitory concentration: 200 nM
Compound 3: middle estimate and measured number agree at the digits printed; measured number inside the range.
By their numbers in this assay, from the lowest: compounds 2, 3 and 1 (each within the scatter of the next).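

In this assay, among these compounds, the move from methyl to ethyl gives a 1.1-fold higher number from compound 2 to compound 3 (0.05 log units; within the scatter), the first reading of a single change in this set, as no earlier pair differed in only one place. It shows that, in this assay, one added carbon at this spot on the 3-methylphenyl group produces no difference that can be told from ordinary repeat-to-repeat variation, so compound 2 and compound 3 cannot be ranked against each other. There is no independent measurement that could explain this result, so the finding stands only as an observation about the two numbers.

The compounds shown leave open how a longer chain such as propyl, a branched group such as isopropyl, or a group of a different kind such as an amine or a carboxylic acid would read in place of the ethyl group. A single small step cannot show how large a group this position can carry before the number moves beyond the scatter, or in which direction it would then go.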